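Aryl change on the ring amine nitrogen: compound 3

The compounds below may be only part of what the source reports. "The series", "measured", "known", "first", "only" and "open" are said of these compounds alone.

In a functional assay on CHO cells with adenosine receptor A1 (Homo sapiens) as the target, read by cAMP accumulation and immunoassay, with a stated time of 6 min, tested at 0.1 uM (a lower number here means a stronger effect, a higher number a weaker effect of the compound at the concentration tested), compound 1 `Nc1scc(CN2CCN(c3c(F)cccc3F)CC2)c1C(=O)c1ccc(Cl)cc1` gives -23%. Compound 2 `Nc1scc(CN2CCN(c3cc(F)ccc3F)CC2)c1C(=O)c1ccc(Cl)cc1` gives -13% in this assay and stands at the upper end of the two numbers, with compound 1 nearest; the step of a number 10 percentage points higher from compound 1 to compound 2 (within the scatter). Compound 3 `Nc1scc(CN2CCN(c3ccccc3Cl)CC2)c1C(=O)c1ccc(Cl)cc1` differs from compound 2 in one place: 2-chlorophenyl in place of 2,5-difluorophenyl on an amine nitrogen in a ring. Within the data shown here, the only measured step also changes the ring on the amine nitrogen and stayed within the scatter, so for compound 3 no step beyond the scatter is expected in this assay; the estimated step is a number 2 percentage points lower from compound 2 to compound 3 (within the scatter). Compound 3 is therefore expected at -15%, within -35% to 5%.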

Compound 3, a percentage reported as activity, at one concentration (the size of the read-out at that concentration, not a potency): 2%
For compound 3 the middle estimate is 17 percentage points below the measured one, within the range that was stated.
By their numbers in this assay, from the lowest: compounds 1 and 2 (each within the scatter of the next); then compound 3.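

On the amine nitrogen in a ring, the aryl group can shift the read-out in this assay: 2-chlorophenyl gives a number 15 percentage points higher from compound 2 to compound 3 (beyond the scatter) and a number 25 percentage points higher from compound 1 to compound 3 (beyond the scatter). Among these compounds, the two difluorophenyl compounds alone showed no step beyond the scatter, so this is the first sign that this position responds to a change of aryl group. Nothing at hand accounts for these steps.

The change swaps two fluorines for one chlorine, so the roles of the halogen and of the number of halogens remain unseparated. Going by these compounds, it also remains open how a plain phenyl, 2-fluorophenyl or 2-methoxyphenyl group would read here.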